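The source may hold more compounds than are shown below. What is called first, only, known or untested is meant among the compounds shown, and "the series" means these compounds.

Among the compounds with values here, compound 3 `CC1(C)C=C(n2ccccc2=O)c2cc(C(=O)c3ccco3)ccc2O1` stands second highest of the three numbers measured so far in a functional assay (aorta) with Rattus norvegicus as the target (on this read-out lower numbers stand for lower potency and higher numbers for higher potency (the scale is a negative logarithm)), where compound 3 gives 6.49. Its nearest neighbour is compound 2 `CC1(C)C=C(n2ccccc2=O)c2cc(C(=O)c3ccccc3)ccc2O1`, which in this assay gives 6.61; the step of a number 0.12 log units lower from compound 2 to compound 3 (within the scatter) is within the scatter. The furthest is compound 1 `CC1(C)C=C(n2ccccc2=O)c2ccccc2O1`, which in this assay gives 5.43; the steps of a number 1.18 log units higher from compound 1 to compound 2 (beyond the scatter) and a number 1.06 log units higher from compound 1 to compound 3 (beyond the scatter) are both beyond the scatter and large.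

Compound 4 `Cc1ccccc1C(=O)c1ccc2c(c1)C(n1ccccc1=O)=CC(C)(C)O2` is the next member and has not yet been measured. It differs from compound 3 in one place: 2-methylphenyl in place of furan-2-yl on a carbonyl carbon. The step that bears most directly on this change is a number 0.12 log units lower from compound 2 to compound 3 (within the scatter), a swap of one aryl group for another on the same carbonyl carbon, which stayed within the scatter. Within the data shown here, both aryl-carbonyl compounds sit well above compound 1, so the carbonyl-bearing pattern itself seems to hold the gain, while the identity of the aryl group made no difference beyond the scatter in the one comparison available. On this basis the author expects for compound 4 a step of a number 0.06 log units higher from compound 3 to compound 4 (within the scatter) that stays within the scatter, with no clear direction. Compound 4 is therefore estimated at 6.55, with a range from 5.95 to 7.15.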

Compound 4, logarithm of the reciprocal of the active concentration, log(1/C): 6.83
Compound 4: middle estimate off by 0.28 log units, on the low side; the range from low to high includes it.
By their numbers in this assay, from the lowest: compound 1; then compounds 3, 2 and 4 (each within the scatter of the next, the first and the last beyond it).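

Swapping the aryl group on the carbonyl carbon can shift the result in this assay after all, since the step of a number 0.34 log units higher from compound 3 to compound 4 (beyond the scatter) is the only aryl-for-aryl change shown here that passes the scatter, with 2-methylphenyl entering and furan-2-yl leaving. The methyl group alone gives no separable effect, as the step of a number 0.22 log units higher from compound 2 to compound 4 (within the scatter) stays within the scatter and compound 2 lies within the scatter of both compound 3 and compound 4, so only the two outer members of this set of aryl-carbonyl compounds are told apart. The (2-methylphenyl)carbonyl group also keeps the large gain over hydrogen on the aromatic carbon, with the step of a number 1.40 log units higher from compound 1 to compound 4 (beyond the scatter) matching the pattern of the other aryl-carbonyl compounds, while no measurement offered here accounts for any of these differences.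

On these data alone, every compound with a group at this aromatic carbon carries an aryl-carbonyl, so it stays open whether a nitrile or a plain alkyl chain there would keep the gain. As far as these compounds go, it also stays open whether a methoxy group or a chlorine in place of the methyl on the 2-methylphenyl group would hold the same level.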